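This account rests on a few compounds, and the source may have more. Where it says the series, first, only, none or still open, it means among the compounds named here.

Compound 1 `COc1ccccc1[S+]([O-])c1cccc(N)c1C#N`: > 200000 nM
Compound 2 `Cc1ccccc1[S+]([O-])c1cccc(N)c1C#N`: > 200000 nM
Compound 3 `N#Cc1c(N)cccc1[S+]([O-])c1ccccc1Br`: 168000 nM

In a functional assay on MT4 cells (Homo sapiens) for cytotoxicity (on this read-out lower numbers stand for stronger inhibition and higher numbers for weaker inhibition), compound 1 gives > 200000 nM, which is a limit and not a number. Compound 2 gives > 200000 nM, also a limit. Among the measured compounds shown here, compound 3, at 168000 nM, carries the only true number, and the rest of the set sits at the limit of > 200000 nM in this assay, at which 2 of the 3 values shown sit.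

Compound 4 `N#Cc1ccccc1[S+]([O-])c1cccc(N)c1C#N` differs from compound 3 by cyano in place of bromo on an aromatic carbon: cyano in place of bromo, ortho to a large group. The bearing steps are an at least 1.1-fold lower number from compound 1 to compound 3 (0.07 log units; that floor lies within the scatter) and an at least 1.1-fold lower number from compound 2 to compound 3 (0.07 log units; that floor lies within the scatter), both known only as floors. The step that the two limits leave unreadable from compound 1 to compound 2 adds nothing.

In this assay the expected change is small, with no step beyond the scatter, and a limit result is likely. The estimated step is a 1.2-fold higher number from compound 3 to compound 4 (0.08 log units; within the scatter). For compound 4 the estimate is 200000 nM, with an expected range of 110000 nM to 350000 nM.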

Compound 4, half-maximal inhibitory concentration: > 200000 nM
Compound 4: only a limit was reported; the forecaster's own chance of this, stated with the estimate: 65%; the middle value lies on the limit itself.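

In this assay, cyano in place of bromo on this aromatic carbon gives an at least 1.1-fold higher number from compound 3 to compound 4 (0.07 log units; that floor lies within the scatter). The steps from compound 1 and from compound 2 to compound 4 cannot be read. Cyano now joins methoxy and methyl at the limit, and bromo in compound 3 remains the only group on this carbon with a true number: the limit of > 200000 nM in this assay, at which 3 of the 4 values shown sit.

From the compounds shown here alone, whether any group on this carbon moves the read-out beyond the scatter stays open. Going by these compounds, an amine or a carboxylic acid here would test this, and the size of either step is unknown.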